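Ester-to-anilide step in a triazole-phenol series

The source may report more compounds than this note shows. Statements on the series, on what has been measured and on what is new or still open speak of the compounds shown alone.

Measured so far:
- compound 1 `COC(=O)c1cc(-n2cc(-c3cc(O)ccc3O)nn2)ccc1O`: 15%
- compound 2 `COC(=O)c1cc(-n2cc(-c3cc(OC)cc(OC)c3)nn2)ccc1O`: 3%

In a functional assay on HCT-116 cells (Homo sapiens) for inhibition, read by MTT assay, with a stated time of 2 days, tested at 10 uM (a lower number here means less inhibition, a higher number more inhibition at the concentration tested (going by the name of the read-out)), compound 2 stands lowest of the two numbers; compound 1 sits a step above it, beyond the scatter. Compound 3 `COc1cc(OC)cc(-c2cn(-c3ccc(O)c(C(=O)Nc4cccc(C(F)(F)F)c4)c3)nn2)c1` is not yet measured. It differs from compound 2 in one place: (3-(trifluoromethyl)phenyl)amino in place of methoxy on a carbonyl carbon. Among the compounds with values here, no measured pair shows this change, so its size is unknown. A modest rise in this assay is expected from compound 2 to compound 3, a number 12 percentage points higher from compound 2 to compound 3 (beyond the scatter), with little weight. Compound 3 is estimated at 15%, range 0% to 45%.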

Compound 3, a percentage reported as inhibition, at one concentration (the size of the read-out at that concentration, not a potency): 62%
Compound 3: the middle estimate sits 47 percentage points below what was measured, and the stated range ends below it.
By their numbers in this assay, from the lowest: compound 2; then compound 1; then compound 3.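

In this assay, (3-(trifluoromethyl)phenyl)amino in place of methoxy on the carbonyl carbon gives a number 59 percentage points higher from compound 2 to compound 3 (beyond the scatter), the first step read at this position, since compounds 1 and 2 both carry methoxy there. The position can therefore carry a large change in inhibition at the concentration tested. Nothing measured here bears on the reason for this step.

A ring, the amide hydrogen and the trifluoromethyl group enter together, and the compounds shown do not separate them. As far as these compounds go, whether a plain phenylamino or a methylamino group gives a similar step remains open.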